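Amide Nitrogen Aryl Swap: Compound 3 to Compound 4

The compounds below may be only part of what the source reports. "The series", "measured", "known", "first", "only" and "open" are said of these compounds alone.

Compound 3 `COc1ccc(-n2nc(C(=O)Nc3ccc(C)cc3)nc2-c2cc(OC)c(OC)c(OC)c2)cc1` carries the lowest of the three numbers in a functional assay on the whole organism for inhibition, with Rattus norvegicus as the target, read by paw edema, with stated times of 30 min and 5 h, at a dose of 0.28 mmol/kg by the oral route (on this read-out higher numbers stand for more inhibition at the one dose given (going by the name of the read-out) and lower numbers for less inhibition), giving 42%, though it lies within the scatter of both others. Compound 1 `CNC(=O)c1nc(-c2cc(OC)c(OC)c(OC)c2)n(-c2ccc(OC)cc2)n1` gives 50% and compound 2 `CCNC(=O)c1nc(-c2cc(OC)c(OC)c(OC)c2)n(-c2ccc(OC)cc2)n1` gives 52%; the step of a number 8 percentage points lower from compound 1 to compound 3 (within the scatter) and the step of a number 10 percentage points lower from compound 2 to compound 3 (within the scatter) stay within the scatter, as does a number 2 percentage points higher from compound 1 to compound 2 (within the scatter). Compound 4 `COc1ccc(-n2nc(C(=O)Nc3cccc(F)c3)nc2-c2cc(OC)c(OC)c(OC)c2)cc1` differs from compound 3 by 3-fluorophenyl in place of 4-methylphenyl on an amide-type nitrogen. Among the compounds with values here, no measured step exchanges one aryl group for another on the amide-type nitrogen; the steps that touch this nitrogen, from methyl or ethyl to 4-methylphenyl, moved the read-out within the scatter only. Compound 4 is therefore expected to give 43%, with a range from 27% to 59%, an expected step of a number 1 percentage points higher from compound 3 to compound 4 (within the scatter) of no size beyond the scatter.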

Compound 4, a percentage reported as inhibition, in the whole organism at one dose (the size of the read-out at that dose, not a potency): 53%
For compound 4 the middle estimate is 10 percentage points below the measured one; the measured number falls inside the stated range.
By their numbers in this assay, from the lowest: compounds 3, 1, 2 and 4 (each within the scatter of the next, the first and the last beyond it).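

In this assay, within the data shown here, exchanging one aryl group for another on the amide-type nitrogen gives a number 11 percentage points higher from compound 3 to compound 4 (beyond the scatter), the first step beyond the scatter, so this position responds to which aryl group it carries. Against the smaller groups, 3-fluorophenyl gives a number 1 percentage points higher from compound 2 to compound 4 (within the scatter) and a number 3 percentage points higher from compound 1 to compound 4 (within the scatter), so an aryl group here can sit level with ethyl and methyl. No measurement at hand accounts for the difference between the two aryl groups.

On these data alone, what 4-fluorophenyl or 3-methylphenyl would give on this nitrogen stays open, so the exchanged group cannot be parted from where it sits on the ring.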